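From compound 3 to compound 4: a shorter chain

The source may hold more compounds than are shown below. What is called first, only, known or untested is meant among the compounds shown, and "the series" means these compounds.

Values in a functional assay on MDA-MB-231 cells (Homo sapiens) for inhibition, read by MTT assay, with a stated time of 48 h (on this read-out lower numbers stand for stronger inhibition and higher numbers for weaker inhibition), so far
compound 1 (`COc1ccc(N(C)c2nc(C)nc3ccccc23)cc1C(=O)OCC[Se]C#N`) 1480 nM
compound 2 (`COc1ccc(N(C)c2nc(C)nc3ccccc23)cc1C(=O)OCCCC[Se]C#N`) 554 nM
compound 3 (`COc1ccc(N(C)c2nc(C)nc3ccccc23)cc1C(=O)OCCCCCC[Se]C#N`) 2210 nM

Compound 3 gives 2210 nM in this assay and its place is fixed by two steps: a 1.5-fold higher number from compound 1 to compound 3 (0.17 log units; within the scatter) and a 4.0-fold higher number from compound 2 to compound 3 (0.60 log units; beyond the scatter). Compound 4 (`COc1ccc(N(C)c2nc(C)nc3ccccc23)cc1C(=O)OCCCCC[Se]C#N`) carries a group of 3 heavy atoms (1 carbon, 1 nitrogen, 1 selenium; no ring) in place of a group of 4 heavy atoms (2 carbon, 1 nitrogen, 1 selenium; no ring), on a saturated chain carbon, five bonds along the chain from an oxygen next to a carbonyl group and so has a chain length that falls between those of compound 2 and compound 3. The series does not run in one direction: a 2.7-fold lower number from compound 1 to compound 2 (0.43 log units; beyond the scatter) is followed by a 4.0-fold higher number from compound 2 to compound 3 (0.60 log units; beyond the scatter). Compound 4 should therefore land between those two values, and the expected change is a 2.0-fold lower number from compound 3 to compound 4 (0.30 log units; within the scatter), toward a lower number. Compound 4 is estimated at 1100 nM, with an expected range from 450 nM to 2600 nM in this assay.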

Compound 4, half-maximal inhibitory concentration: 851 nM
The estimate for compound 4 lay 1.3-fold (0.11 log units) above the measured number; low and high end bracket the measured number.
By their numbers in this assay, from the lowest: compounds 2, 4, 1 and 3 (each within the scatter of the next, the first and the last beyond it).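

In this assay, the chain of compound 4 differs from that of compound 3 by a single carbon, and this small change gives a step beyond the scatter (a 2.6-fold lower number from compound 3 to compound 4 (0.41 log units; beyond the scatter)). The shorter chains are not separated from compound 4 in the same way, as both remaining steps lie within the scatter (a 1.5-fold higher number from compound 2 to compound 4 (0.19 log units; within the scatter); a 1.7-fold lower number from compound 1 to compound 4 (0.24 log units; within the scatter)). The sharpest chain-length effect around compound 4 therefore lies on the side of compound 3.

The compounds shown leave open how a longer chain or a thiocyanate end group would read out. Nothing available here accounts for this dependence on chain length.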